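Chloro for hydrogen on the fused core: second analogue pair

The source may report more compounds than this note shows. Statements on the series, on what has been measured and on what is new or still open speak of the compounds shown alone.

Measured so far:
Compound 1 `ClCc1cccc(Cn2cnc3c(Cl)ncnc32)c1` gives 3230 nM in a functional assay on HT-29 cells (Homo sapiens) for cytotoxicity, read by sulforhodamine B assay, with a stated time of 48 h; on this read-out higher numbers stand for weaker inhibition of growth and lower numbers for stronger inhibition of growth.
Compound 2 `ClCc1cccc(Cn2cnc3c(Cl)nc(Cl)nc32)c1` gives 2390 nM in this assay.
Compound 3 `ClCc1ccccc1Cn1cnc2ncnc(Cl)c21` gives 3890 nM in this assay.

The three numbers sit within the scatter of one another, so no ranking among compound 1, compound 2 and compound 3 is supported. Compound 2 differs from compound 1 by chloro in place of hydrogen on an aromatic carbon; the step is a 1.4-fold lower number from compound 1 to compound 2 (0.13 log units; within the scatter). Compound 3 has the same atoms as compound 1 joined differently; the difference between the two cores is not broken down here.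

Compound 4 `ClCc1ccccc1Cn1cnc2nc(Cl)nc(Cl)c21` is not yet measured. It differs from compound 3 by chloro in place of hydrogen on an aromatic carbon, the same change as from compound 1 to compound 2, at a place described in the same words. Among the measured compounds shown here, for compound 4 the step expected in this assay is a 1.4-fold lower number from compound 3 to compound 4 (0.14 log units; within the scatter), resting on the single earlier step of a 1.4-fold lower number from compound 1 to compound 2 (0.13 log units; within the scatter), which itself lies within the scatter. Compound 4 is accordingly estimated at 2800 nM, with an expected range from 1400 nM to 5600 nM.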

Compound 4, concentration for 50% growth inhibition: 400 nM
Estimate against measurement, compound 4: 7.0-fold (0.85 log units) above; measured number below the stated range.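

In this assay the change of chloro in place of hydrogen gives a 9.7-fold lower number from compound 3 to compound 4 (0.99 log units; beyond the scatter), so the size of the step on the core of compound 1 does not carry over to the core of compound 3: the same change on two cores in this assay, a 1.4-fold lower number (0.13 log units; within the scatter) from compound 1 to compound 2 and a 9.7-fold lower number (0.99 log units; beyond the scatter) from compound 3 to compound 4, 7.2-fold (0.86 log units) apart, beyond the scatter of two such steps. For these two pairs the step therefore depends on the core that carries it, and a step read on one core is a poor guide to the same change on the other. This does not show why the cores part, since the two pairs offer no measure of what sets them apart, and two pairs give no rule for any further core.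

Going by these compounds, whether the larger step is particular to chloro on the aromatic carbon between two ring nitrogen atoms remains open, as does the part played by the chloromethyl group. An amine or a methoxy group on that carbon of compound 4, or a methyl group in place of chloromethyl, would bear on these questions.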